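Swapping the Terminal Group on the Amide Nitrogen

The source may hold more compounds than are shown below. What is called first, only, known or untested is meant among the compounds shown, and "the series" means these compounds.

Of the compounds shown here, two have been measured in a functional assay on SW-620 cells (Homo sapiens) for inhibition, read by MTT assay, with a stated time of 72 h; on this read-out higher numbers stand for weaker inhibition and lower numbers for stronger inhibition. Compound 1 `COc1cc(NC(C)CCCNC(=O)NNC(=O)Nc2cc(C(F)(F)F)cc(C(F)(F)F)c2)c2ncccc2c1` gives 16000 nM in this assay, and compound 2 `COc1cc(NC(C)CCCNC(=O)Nc2ccc(O)cc2)c2ncccc2c1` gives 30000 nM; these two numbers lie within the usual scatter of each other, so compound 2 does not stand apart on the numbers shown. Compound 3 `COc1cc(NC(C)CCCNC(=O)NNC(=O)Nc2ccc(F)cc2)c2ncccc2c1` has not yet been measured. It differs from compound 2 in one place: ((4-fluorophenyl)carbamoyl)amino in place of 4-hydroxyphenyl on an amide-type nitrogen. Among the measured compounds shown here, no step between measured compounds is available for guidance; the step of a 1.5-fold lower number from compound 2 to compound 3 (0.18 log units; within the scatter) is therefore expected to be small, not beyond the scatter in either direction. Compound 3 is estimated at 20000 nM, with a range from 8000 nM to 50000 nM.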

Compound 3, half-maximal inhibitory concentration: > 100000 nM
Compound 3: only a limit was reported; the forecaster's own chance of this, stated with the estimate: 10%; at least 5.0-fold (0.69 log units) between middle value and limit.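

In this assay, exchanging the 4-hydroxyphenyl group for ((4-fluorophenyl)carbamoyl)amino on an amide-type nitrogen gives an at least 3.3-fold higher number from compound 2 to compound 3 (0.52 log units; beyond the scatter). The earlier compounds shown here, whose values lay within the scatter of each other, gave no sign that a change at this position could separate compounds. The value of compound 3 is a limit of the assay: the limit of > 100000 nM in this assay, at which 1 of the 3 values shown sits.

Still open, from the compounds shown here alone, is whether the fluorine or the added carbamoyl-amino part carries this step. A plain 4-fluorophenyl on the same nitrogen, or an amine in place of the fluorine, would bear on that question.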